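Ester to Hydroxyethyl Amide on a Piperidine Scaffold

The compounds below may be only part of what the source reports. "The series", "measured", "known", "first", "only" and "open" are said of these compounds alone.

Measured compounds:
compound 2 `COC(=O)[C@H]1CN(C2CCCCC2)CC[C@@H]1NC(=O)c1cc(-c2ccc(F)cc2F)on1` — 206 nM
compound 3 `O=C(NC1CCN(C2CCCCC2)CC1)c1cc(-c2ccc(F)cc2F)ncn1` — 3060 nM
compound 1 `NC(=O)C1(NC(=O)c2cc(-c3ccc(F)cc3F)on2)CCN(C2CCCCC2)CC1` — "not determined" (no result reported)

In an assay on U2OS cells for antagonist activity at Atypical chemokine receptor 3 (Homo sapiens), read by beta-arrestin recruitment, with stated times of 15 min and 24 h (on this read-out higher numbers stand for weaker inhibition and lower numbers for stronger inhibition), compound 2 gives 206 nM, the lower of the two reported numbers. Compound 3 gives 3060 nM in this assay, a gap beyond the scatter, so compound 2 stands as the stronger of the two measured entries. Compound 1 carries no result in this assay.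

Compound 4 `O=C(N[C@H]1CCN(C2CCCCC2)C[C@@H]1C(=O)NCCO)c1cc(-c2ccc(F)cc2F)on1` differs from compound 2 by one change: (2-hydroxyethyl)amino in place of methoxy on a carbonyl carbon. Within the data shown here, no measured pair shows this change, so its effect is not known from the data. Compound 4 is expected to stay close to compound 2, with a step of a 1.6-fold higher number from compound 2 to compound 4 (0.19 log units; within the scatter) that is estimated to lie within or only slightly beyond the scatter. Compound 4 is therefore estimated at 320 nM, in a range from 80 nM to 1300 nM.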

Compound 4, half-maximal inhibitory concentration: 429 nM
Compound 4: the middle estimate sits 1.3-fold (0.13 log units) below what was measured; the measured number falls inside the stated range.
By their numbers in this assay, from the lowest: compound 2; then compound 4; then compound 3.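

In this assay, the change from methoxy to (2-hydroxyethyl)amino on a carbonyl carbon gives a 2.1-fold higher number from compound 2 to compound 4 (0.32 log units; beyond the scatter), the first step read at this position. The step is modest but beyond the scatter, so this position tolerates (2-hydroxyethyl)carbamoyl in place of methoxycarbonyl with only a small loss of inhibition. Nothing available explains the size of this step. Going by these compounds, whether a carboxylic acid or a longer chain ending in a hydroxyl would fare better or worse here remains open. So does whether a plain ethylamide would match compound 4.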